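Amide-nitrogen substituent change in a nitrile-bearing series

A few compounds are considered here, and "the series" means these few. Any claim that something is new, unique, unknown or untested is made for them only; others in the source may bear on it.

Measured so far:
compound 1: `COc1cc(Cl)c(-c2nc(SCC(=O)NC3CC3)nc3[nH]cc(C#N)c23)cc1OC`, 62 nM
compound 2: `CCOc1cc(-c2nc(SCC(=O)NC3CC3)nc3[nH]cc(C#N)c23)c(Cl)cc1OC`, 23 nM

In a functional assay on MDA-MB-468 cells (Homo sapiens) for antiproliferative activity, read by sulforhodamine B assay, with a stated time of 4 days (on this read-out lower numbers stand for stronger inhibition of growth and higher numbers for weaker inhibition of growth), compound 2 holds the lowest of the two numbers, with compound 1 nearest. Among the measured compounds shown here, the single measured step, a 2.7-fold lower number from compound 1 to compound 2 (0.43 log units; beyond the scatter), concerns the alkoxy chain and not the amide substituent. Compound 3, `CCOc1cc(-c2nc(SCC(=O)NC(C)C)nc3[nH]cc(C#N)c23)c(Cl)cc1OC`, differs from compound 2 by isopropyl in place of cyclopropyl on an amide-type nitrogen. No measured step touches this group, so nothing shown bears directly on it; with no guide, the expected step of a 1.1-fold higher number from compound 2 to compound 3 (0.04 log units; within the scatter) is no change beyond the scatter. Compound 3 is therefore estimated at 25 nM, within 10 nM to 65 nM.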

Compound 3, concentration for 50% growth inhibition: 77 nM
Compound 3: middle estimate off by 3.1-fold (0.49 log units), on the low side; measured number outside the range, above it.
By their numbers in this assay, from the lowest: compound 2; then compounds 1 and 3 (each within the scatter of the next).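

In this assay, isopropyl in place of cyclopropyl on the amide-type nitrogen gives a 3.3-fold higher number from compound 2 to compound 3 (0.52 log units; beyond the scatter) with the heavy-atom count unchanged. This position therefore responds to the substituent, even though the change removes only the three-membered ring and adds no hydrogen-bond donors or acceptors. Nothing measured on these compounds accounts for the step.

Among the compounds shown here, only this single pair covers the amide nitrogen. Going by these compounds, how cyclobutyl, ethyl or a longer chain ending in an amine would compare with cyclopropyl here remains open, as does whether the step carries over to other alkoxy groups.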